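The compounds below may be only part of what the source reports. "The series", "measured", "known", "first", "only" and "open" are said of these compounds alone.

In a functional assay (on this read-out lower numbers stand for stronger inhibition and higher numbers for weaker inhibition), compound 1 `CC(C)=CCOc1ccc2c(c1)OC(c1ccccc1)CC2=O` gives 6070 nM. Compound 2 `CC(C)=CCOc1ccc2c(c1)OC(c1cccc(F)c1)CC2=O`, with fluoro in place of hydrogen on an aromatic carbon, gives 4280 nM. The change between them is a 1.4-fold lower number from compound 1 to compound 2 (0.15 log units; within the scatter). Within the data shown here, compound 2 has the lower of only two numbers, but the pair cannot really be told apart, since repeat measurements alone could produce a gap of this size.

Compound 3 `CC(C)=CCOc1ccc2c(c1)OC(c1ccc(F)cc1)CC2=O` has not yet been measured. It contains the same atoms as compound 2, joined differently: 4-fluorophenyl in place of 3-fluorophenyl on a saturated ring carbon. In plain terms, 4-fluorophenyl stands in place of 3-fluorophenyl on a saturated ring carbon.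

Among the measured compounds shown here, no measured pair shows this exact change, so the only guide is the earlier fluoro step. A small effect is expected from moving the fluoro because a 1.4-fold lower number from compound 1 to compound 2 (0.15 log units; within the scatter) stayed within the scatter. That is indirect evidence, so the range must stay wide. The estimate is therefore for no shift beyond the scatter in either direction, with the expected change being a 1.1-fold higher number from compound 2 to compound 3 (0.02 log units; within the scatter). In this assay, the estimated value for compound 3 is 4500 nM, with a likely range from 2000 nM to 10000 nM.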

Compound 3, half-maximal inhibitory concentration: 7320 nM
For compound 3 the middle estimate is 1.6-fold (0.21 log units) below the measured one; the range from low to high includes it.
By their numbers in this assay, from the lowest: compounds 2, 1 and 3 (each within the scatter of the next).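

Swapping 3-fluorophenyl for 4-fluorophenyl on this saturated ring carbon gives a 1.7-fold higher number from compound 2 to compound 3 (0.23 log units; within the scatter) in this assay, so these two fluorinated compounds cannot be told apart on this read-out. Comparing 4-fluorophenyl with plain phenyl at the same carbon gives a 1.2-fold higher number from compound 1 to compound 3 (0.08 log units; within the scatter), which means that neither fluorinated compound can be separated from the compound without fluoro, and that compounds 1, 2 and 3 all read as one level of inhibition within normal measurement noise. Nothing available helps to interpret the small gaps among these three compounds.

The compounds shown place only hydrogen or fluoro on this phenyl ring, so it remains open whether a different substituent, such as a methoxy group, an amine or a carboxylic acid, would produce a step clearly beyond the scatter. From the compounds shown here alone, it is also open whether replacing the whole phenyl ring with a pyridine ring, or with a simple saturated chain, would change the number, and so how much this position matters for inhibition at all.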